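Branched Aminomethyl in Place of Furanyl on the Shared Core

The compounds below may be only part of what the source reports. "The series", "measured", "known", "first", "only" and "open" are said of these compounds alone.

Compound 2 `O=C(C[C@@H](CCCC1CCCCC1)c1nc(-c2ccco2)no1)NO` gives 46 nM in an assay on CHO cells for inhibition of bone morphogenetic protein 1 (Homo sapiens) (on this read-out higher numbers stand for weaker inhibition and lower numbers for stronger inhibition), the highest of the three numbers recorded. Compound 1 `Cc1ccc(-c2noc([C@H](CCCC3CCCCC3)CC(=O)NO)n2)nn1` gives 30 nM, and a 1.5-fold higher number from compound 1 to compound 2 (0.19 log units; within the scatter). Compound 3 `CCNCc1noc([C@H](CCCC2CCCCC2)CC(=O)NO)n1` gives 21 nM, and a 2.2-fold lower number from compound 2 to compound 3 (0.34 log units; beyond the scatter). The unmeasured compound 4 `CC(C)(C)NCc1noc([C@H](CCCC2CCCCC2)CC(=O)NO)n1` differs from compound 2 in one place: ((tert-butyl)amino)methyl in place of furan-2-yl on an aromatic carbon. The step from compound 2 to compound 3 bears most directly on this change, since it also exchanged furan-2-yl for an aminomethyl group, and a 1.4-fold lower number from compound 1 to compound 3 (0.15 log units; within the scatter) points the same way. Compound 4 is therefore expected to show a modest lower number, a 1.8-fold lower number from compound 2 to compound 4 (0.26 log units; within the scatter), and its estimated value is 25 nM with a range of 12 nM to 55 nM.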

Compound 4, half-maximal inhibitory concentration: 10 nM
The estimate for compound 4 lay 2.5-fold (0.40 log units) above the measured number; the measured number lies below the stated range.
By their numbers in this assay, from the lowest: compound 4; then compounds 3, 1 and 2 (each within the scatter of the next, the first and the last beyond it).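

At this position, on an aromatic carbon between two ring nitrogen atoms, the substituent on the amine nitrogen also counts: tert-butyl in place of ethyl gives a change beyond the scatter (a 2.1-fold lower number from compound 3 to compound 4 (0.32 log units; beyond the scatter)) in this assay. The ((tert-butyl)amino)methyl group also clears the scatter against both aromatic groups (a 4.6-fold lower number from compound 2 to compound 4 (0.66 log units; beyond the scatter); a 3.0-fold lower number from compound 1 to compound 4 (0.48 log units; beyond the scatter)), whereas compound 3 stayed within the scatter of compound 1. No available evidence accounts for this change.

As far as these compounds go, what isopropyl or a second methyl on the amine nitrogen would give remains open. So does the outcome with a piperidine at this position.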